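Ethoxycarbonyl for methyl on the pendant aryl of compound 1

The compounds below may be only part of what the source reports. "The series", "measured", "known", "first", "only" and "open" are said of these compounds alone.

Working notes on the series. Among the compounds with values here, of the three measured compounds, compound 1 `COc1cc(-c2ccnc3cc(-c4ccc(C)cc4)nn23)cc(OC)c1OC` is the only one to give a number in a functional assay on HeLa cells (Homo sapiens) for inhibition, read by CCK-8 assay, with a stated time of 48 h; a lower number here means a stronger inhibitor, a higher number a weaker inhibitor: compound 1 gives 21 nM. Compound 2 `COc1cc(-c2ccnc3c(-c4ccc(C)cc4)cnn23)cc(OC)c1OC` returns only a limit of the assay in this assay, > 10000 nM. Compound 3 `COc1ccc(-c2cc3nccc(-c4cc(OC)c(OC)c(OC)c4)n3n2)cc1[N+](=O)[O-]` likewise returns only a limit of the assay in this assay, > 10000 nM. Within the data shown here, two of the three values therefore sit at the limit of > 10000 nM in this assay, at which 2 of the 3 values shown sit, and no pair of measured compounds differs in a single place, so no measured step can be pointed to for the size of any change. Compound 4 `CCOC(=O)c1ccc(-c2cc3nccc(-c4cc(OC)c(OC)c(OC)c4)n3n2)cc1` is not yet measured; it differs from compound 1 in one place: ethoxycarbonyl in place of methyl on an aromatic carbon. Among the measured compounds shown here, with no measured step to lean on, the expectation for compound 4 rests on compound 1 alone at 21 nM. The expected step is a 3.8-fold higher number from compound 1 to compound 4 (0.58 log units; beyond the scatter), a moderate loss rather than none. Compound 4 is estimated at 80 nM, within 15 nM to 800 nM.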

Compound 4, half-maximal inhibitory concentration: > 10000 nM
Compound 4 gave a limit, no number; the forecaster's own chance of this, stated with the estimate: 15%; middle value at least 120-fold (2.09 log units) from the limit.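

In this assay compound 4 returns only a limit of the assay, > 10000 nM. Within the data shown here, this is the only measured change in one place so far: on an aromatic carbon para to a large group, ethoxycarbonyl in place of methyl gives an at least 470-fold higher number from compound 1 to compound 4 (2.67 log units; beyond the scatter), so the activity of compound 1 does not survive every substituent here. The step is a lower bound and its true size cannot be read, as the result ends at the assay's limit, where most of the series now sits: the limit of > 10000 nM in this assay, at which 3 of the 4 values shown sit.

Still open, going by these compounds, is whether any group beyond methyl is accepted at this position, or whether the loss is specific to ethoxycarbonyl. An ethyl chain, a chlorine, an amine or a carboxylic acid on the same carbon would separate these readings.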